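Sulfonylurea variations at the sulfonyl sulfur on a shared core

The compounds below may be only part of what the source reports. "The series", "measured", "known", "first", "only" and "open" are said of these compounds alone.

Three compounds share one core and differ only in the group on the sulfonyl sulfur. In an assay on liver for inhibition of sterol O-acyltransferase 1 (Rattus norvegicus), using microsomes (on this read-out lower numbers stand for stronger inhibition and higher numbers for weaker inhibition), compound 1 `CC(C)NS(=O)(=O)NC(=O)Nc1c(C(C)C)cccc1C(C)C` gives 18000 nM, compound 2 `CCCCN(C)S(=O)(=O)NC(=O)Nc1c(C(C)C)cccc1C(C)C` gives 2300 nM, and compound 3 `CC(C)c1cccc(C(C)C)c1NC(=O)NS(=O)(=O)N1CCCCC1` gives 17000 nM. Compound 3 stands second highest of the three numbers: compound 1 is its nearest neighbour, a gap within the scatter, and compound 2 is furthest, as a 7.4-fold higher number from compound 2 to compound 3 (0.87 log units; beyond the scatter) shows.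

Compound 4 `CC(C)c1cccc(C(C)C)c1NC(=O)NS(=O)(=O)N(C(C)C)C(C)(C)C` carries the change (isopropyl(tert-butyl)amino in place of piperidin-1-yl on a sulfonyl sulfur). Two earlier steps at the same position bear on it: a 1.1-fold lower number from compound 1 to compound 3 (0.02 log units; within the scatter) lay within the scatter, while a 7.8-fold lower number from compound 1 to compound 2 (0.89 log units; beyond the scatter) was beyond it. Within the data shown here, the one acyclic group with two substituents on the nitrogen, in compound 2, gave the lowest number, so a modest move in that direction is plausible, but the branched group of compound 4 has no close precedent. For compound 4 the expected step is a 2.1-fold lower number from compound 3 to compound 4 (0.33 log units; beyond the scatter), and its estimated value in this assay is 8000 nM, within a range from 2000 nM to 30000 nM.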

Compound 4, half-maximal inhibitory concentration: 140 nM
Compound 4: the middle estimate sits 57-fold (1.76 log units) above what was measured; measured number outside the range, below it.
By their numbers in this assay, from the lowest: compound 4; then compound 2; then compounds 3 and 1 (each within the scatter of the next).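

Swapping piperidin-1-yl for isopropyl(tert-butyl)amino on the sulfonyl sulfur gives a 120-fold lower number from compound 3 to compound 4 (2.08 log units; beyond the scatter), so this position can shift the number much further than the earlier compounds showed. Branching matters among open-chain groups too, since butyl(methyl)amino also gives way to a large gain, a 16-fold lower number from compound 2 to compound 4 (1.22 log units; beyond the scatter). Placing tert-butyl in place of hydrogen on a sulfonamide nitrogen, with the isopropyl group kept, gives a 130-fold lower number from compound 1 to compound 4 (2.11 log units; beyond the scatter), which shows that this single addition is enough to produce a large step, though nothing shown explains why it does so.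

As far as these compounds go, it remains open whether both branched groups are needed, which diisopropylamino or tert-butyl(methyl)amino on the sulfur would help to separate. It is also unclear how far the trend extends, for example to di-tert-butylamino or to a branched ring such as 2,2,6,6-tetramethylpiperidin-1-yl.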